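The source may hold more compounds than are shown below. What is called first, only, known or untested is meant among the compounds shown, and "the series" means these compounds.

Measured in a functional assay on A2780 cells (Homo sapiens) for antiproliferative activity, read by sulforhodamine B assay, with a stated time of 72 h; a higher number here means a weaker inhibitor, a lower number a stronger inhibitor:
- Compound 1 `Cc1ncccc1CNC(=O)Nc1ccc(S(=O)(=O)c2ccccc2)cc1`: > 2000 nM
- Compound 2 `C[C@@H]1CN(S(=O)(=O)c2ccc(NC(=O)NCc3cccnc3)cc2)C[C@H](C)O1`: 15 nM

The entry of compound 1, > 2000 nM, is a limit of the assay and not a number. Among the compounds with values here, compound 2, at 15 nM, holds the only exact value so far. Compound 3 `O=C(NCc1cccnc1)Nc1ccc(S(=O)(=O)N2CCCNCC2)cc1` differs from compound 2 in one place, with 1,4-diazepan-1-yl in place of 2,6-dimethylmorpholin-4-yl on a sulfonyl sulfur. Within the data shown here, no measured pair differs in just one place, so the size of this step is a judgement. A modest weakening in this assay, beyond the scatter, is expected, and the estimated step is a 4.0-fold higher number from compound 2 to compound 3 (0.60 log units; beyond the scatter). Compound 3 is expected at 60 nM, within an estimated range of 12 nM to 300 nM.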

Compound 3, half-maximal inhibitory concentration: 594 nM
Compound 3: middle estimate off by 9.9-fold (1.00 log units), on the low side; measured number above the stated range.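

In this assay, the group on the sulfonyl sulfur is far from a neutral position: 1,4-diazepan-1-yl in place of 2,6-dimethylmorpholin-4-yl gives a 40-fold higher number from compound 2 to compound 3 (1.60 log units; beyond the scatter). This single swap changes several things at once: ring size, an oxygen replaced by a nitrogen that brings a hydrogen-bond donor, and the loss of two defined stereocentres. The data shown do not separate these changes or explain the size of the step. From the compounds shown here alone, whether an unsubstituted morpholin-4-yl or a piperazin-1-yl would stay closer to compound 2 or to compound 3 remains open.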